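This account rests on a few compounds, and the source may have more. Where it says the series, first, only, none or still open, it means among the compounds named here.

Compound 2 `CCOC(=O)C1=Cc2ccccc2OC1(OCc1cn(-c2cccc(C(F)(F)F)c2)nn1)C(F)(F)F` gives only a limit in a functional assay on A549 cells (Homo sapiens) for inhibition, read by MTT assay, with a stated time of 24 h (a higher number here means a weaker inhibitor, a lower number a stronger inhibitor), namely > 150000 nM. Compound 1 `CCOC(=O)C1=Cc2ccccc2OC1(OCc1cn(-c2ccc(F)c(Cl)c2)nn1)C(F)(F)F` in this assay gives 26300 nM. Going by the values given here, the one measured step, an at least 5.7-fold higher number from compound 1 to compound 2 (0.75 log units; beyond the scatter), ends where compound 2 sits, at the limit of > 150000 nM in this assay, at which 1 of the 2 values shown sits. Compound 3 `CCOC(=O)C1=Cc2ccccc2OC1(OCc1cn(CC(=O)Nc2ccc(OC)cc2)nn1)C(F)(F)F` differs from compound 2 by ((4-methoxyphenyl)carbamoyl)methyl in place of 3-(trifluoromethyl)phenyl on an aromatic nitrogen. Among the compounds with values here, no measured step covers an entering group of this kind, so the direction is unclear, and compound 2 itself has no firm number to start from. Compound 3 is therefore expected to land around 80000 nM, within 15000 nM to 300000 nM, which would mean an estimated at least 1.8-fold lower number from compound 2 to compound 3 (0.27 log units; that floor lies within the scatter).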

Compound 3, half-maximal inhibitory concentration: 29400 nM
Estimate against measurement, compound 3: 2.7-fold (0.43 log units) above; the range from low to high includes it.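

The aromatic nitrogen also tolerates a group other than a directly attached aryl ring: with ((4-methoxyphenyl)carbamoyl)methyl there, this assay shows an at least 5.1-fold lower number from compound 2 to compound 3 (0.70 log units; beyond the scatter). The starting point of that step is a limit, not a number: the limit of > 150000 nM in this assay, at which 1 of the 3 values shown sits. Against 3-chloro-4-fluorophenyl, the same group gives a 1.1-fold higher number from compound 1 to compound 3 (0.05 log units; within the scatter), so these two groups cannot be told apart here.

On these data alone, it remains open which part of the entering group matters, and how a carboxylic acid or a longer chain on this nitrogen would read in this assay.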